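A few compounds are considered here, and "the series" means these few. Any claim that something is new, unique, unknown or untested is made for them only; others in the source may bear on it.

Values in a functional assay on MDA-MB-436 cells (Homo sapiens) for antiproliferative activity, read by MTT assay, with a stated time of 48 h (on this read-out higher numbers stand for weaker inhibition and lower numbers for stronger inhibition), so far:
- compound 1 (`C=CS(=O)(=O)N1CCN(c2ncnc3sc(-c4cccc5ccccc45)cc23)CC1`): 28100 nM
- compound 2 (`CN1CCN(c2ccc(-c3cc4c(N5CCN(S(=O)(=O)/C=C/c6ccccc6)CC5)ncnc4s3)cc2)CC1`): 8670 nM

Compound 2 holds the lower of the two numbers (8670 nM), and the gap to compound 1 lies beyond the scatter. Compound 3 (`CN1CCN(c2ccc(-c3cc4c(N5CCN(S(=O)(=O)N6CCCCC6)CC5)ncnc4s3)cc2)CC1`) carries piperidin-1-yl in place of 2-phenylethenyl on a sulfonyl sulfur. For the measured compounds named here, no measured pair isolates this change, so compound 2 (8670 nM) is the only anchor in this assay, and no step larger than the scatter is expected from it. The estimated step, a 1.0-fold higher number from compound 2 to compound 3 (0.02 log units; within the scatter), stays within the scatter. Compound 3 is expected at 9000 nM (estimated range 3500 nM to 25000 nM).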

Compound 3, half-maximal inhibitory concentration: 7570 nM
Estimate against measurement, compound 3: 1.2-fold (0.08 log units) above; low and high end bracket the measured number.
By their numbers in this assay, from the lowest: compounds 3 and 2 (each within the scatter of the next); then compound 1.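

In this assay, piperidin-1-yl in place of 2-phenylethenyl on a sulfonyl sulfur gives a 1.1-fold lower number from compound 2 to compound 3 (0.06 log units; within the scatter). The sulfonyl substituent can therefore go from a six-membered aromatic ring of carbon only and a double bond to a six-membered non-aromatic ring with a nitrogen without the number leaving the scatter. Nothing measured on these compounds gives a reason for this flat step. Still open, going by these compounds, is how a methyl, a dimethylamino group or a morpholin-4-yl ring on the same sulfonyl sulfur would read, and whether a carboxylic acid on the piperidin-1-yl ring would carry the number beyond the scatter.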